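This account rests on a few compounds, and the source may have more. Where it says the series, first, only, none or still open, it means among the compounds named here.

Within the data shown here, in a functional assay on A549 cells (Homo sapiens) for inhibition, read by MTT assay, with a stated time of 72 h (a higher number here means a weaker inhibitor, a lower number a stronger inhibitor), compound 2 `Cn1ccc2c(Oc3ccc(NC(=O)c4cn(-c5ccc(C(F)(F)F)cc5Cl)c5ccccc5c4=O)cc3F)ccnc21` gives 2050 nM, the highest of the three numbers so far. Compound 1 `Cn1ccc2c(Oc3ccc(NC(=O)c4cn(-c5ccc(Cl)cc5)c5ccccc5c4=O)cc3F)ccnc21` gives 250 nM and compound 3 `Cn1ccc2c(Oc3ccc(NC(=O)c4cn(-c5ccc(F)c(Cl)c5)c5ccccc5c4=O)cc3F)ccnc21` gives 1210 nM; the measured steps are an 8.2-fold higher number from compound 1 to compound 2 (0.91 log units; beyond the scatter), a 4.8-fold higher number from compound 1 to compound 3 (0.68 log units; beyond the scatter) and a 1.7-fold lower number from compound 2 to compound 3 (0.23 log units; within the scatter). Compound 4 `O=C(Nc1ccc(Oc2ccnc3[nH]ccc23)c(F)c1)c1cn(-c2ccc(C(F)(F)F)cc2Cl)c2ccccc2c1=O` differs from compound 2 by hydrogen in place of methyl on an aromatic nitrogen. Among the measured compounds shown here, none of the measured steps touches this position; all three vary the aryl group on the other aromatic nitrogen, so no measured step bears on the change directly. For compound 4 the expected step in this assay is therefore a 1.0-fold lower number from compound 2 to compound 4 (0.01 log units; within the scatter), nothing beyond the scatter, with a wide range because of the missing precedent. Compound 4 is estimated at 2000 nM, between 600 nM and 6500 nM.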

Compound 4, half-maximal inhibitory concentration: 1620 nM
Estimate against measurement, compound 4: 1.2-fold (0.09 log units) above; low and high end bracket the measured number.
By their numbers in this assay, from the lowest: compound 1; then compounds 3, 4 and 2 (each within the scatter of the next).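

this assay gives the first reading at this position: hydrogen in place of methyl on an aromatic nitrogen of the five-membered aromatic ring gives a 1.3-fold lower number from compound 2 to compound 4 (0.10 log units; within the scatter) and leaves compound 2 and compound 4 indistinguishable. With the 2-chloro-4-(trifluoromethyl)phenyl group kept, this single pair therefore shows no dependence of the number on the methyl. Nothing at hand explains this result.

Going by these compounds, whether the same holds with the 4-chlorophenyl group of compound 1 remains open. So does the outcome with an ethyl group or a longer chain ending in an amine on this nitrogen.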